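From compound 3 to compound 4: a chloro for hydrogen

The source may hold more compounds than are shown below. What is called first, only, known or untested is meant among the compounds shown, and "the series" means these compounds.

Of the compounds shown here, three sharing one core have been measured in a physicochemical assay for lipophilicity, read by HPLC, tested at 5 mM; on this read-out lower numbers stand for lower lipophilicity and higher numbers for higher lipophilicity. Compound 1 `CC(Oc1ccc(Oc2ccc(Cl)cc2)cc1)C(=O)Cn1nnc(-c2ccccc2)n1` gives 6 and compound 2 `CC(Oc1ccc(Oc2ccc(C(F)(F)F)cc2)cc1)C(=O)Cn1nnc(-c2ccccc2)n1` gives 6.2, a pair whose difference, trifluoromethyl in place of chloro on an aromatic carbon, amounts to a number 0.20 log units higher from compound 1 to compound 2 (within the scatter). Compound 3 `CC(Oc1ccc(-c2ccccc2)cc1)C(=O)Cn1nnc(-c2ccccc2)n1` gives 5.3, the lowest of the three numbers; the steps down to it are a number 0.70 log units lower from compound 1 to compound 3 (beyond the scatter) and a number 0.90 log units lower from compound 2 to compound 3 (beyond the scatter). Compound 4 `CC(Oc1ccc(-c2ccccc2)cc1)C(=O)Cn1nnc(-c2ccc(Cl)cc2)n1` differs from compound 3 by chloro in place of hydrogen on an aromatic carbon, the chloro entering on an aromatic carbon of a six-membered aromatic ring of carbon only, para to a large group. For the measured compounds named here, none of the measured steps adds a chloro where a hydrogen stood: the two steps ending at compound 3 removed whole phenoxy groups, and the step from compound 1 to compound 2 only exchanged chloro for trifluoromethyl, a difference within the scatter. On that basis a modest rise in this assay is expected for compound 4, namely a number 0.60 log units higher from compound 3 to compound 4 (beyond the scatter). Compound 4 is therefore estimated at 5.9, with a range of 5.5 to 6.3.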

Compound 4, partition coefficient: 6.1
Compound 4: middle estimate off by 0.20 log units, on the low side, within the range that was stated.
By their numbers in this assay, from the lowest: compound 3; then compounds 1, 4 and 2 (each within the scatter of the next).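

Compounds 1, 2 and 3 all carry the same unsubstituted phenyl at this position, so compound 4 gives the first view of a change there. In this assay, phenyl to 4-chlorophenyl gives a number 0.80 log units higher from compound 3 to compound 4 (beyond the scatter) and shows that this position responds to substitution. One chlorine atom, entering para to a large group, is enough to move the number beyond the scatter, though no measurement at hand accounts for the size of this step.

Going by these compounds, whether an amine, a carboxylic acid or a methoxy group at the same carbon would shift the number in the same direction remains open. Also open, on these data alone, is whether the same chloro step would hold in compounds carrying the 4-chlorophenoxy or 4-(trifluoromethyl)phenoxy group of compound 1 and compound 2.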